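The source may hold more compounds than are shown below. What is called first, only, known or untested is meant among the compounds shown, and "the series" means these compounds.

Measured so far in a functional assay on BGC-823 cells (Homo sapiens) for antiproliferative activity, read by MTT assay, tested at 1 uM; a higher number here means a stronger effect of the compound at the concentration tested, a lower number a weaker effect:
Compound 1, `COc1cc(C2=NN(C(C)=O)C(c3c(Cl)cccc3Cl)O2)cc(OC)c1OC`, gives -1.4%.
Compound 2, `COc1cc(C2=NN(C(C)=O)C(c3ccc(C(F)(F)F)cc3)O2)cc(OC)c1OC`, gives 4.2%.

Both numbers sit close to zero, meaning almost no inhibition of cell growth at the tested concentration. Among the measured compounds shown here, the only step between them, a number 5.6 percentage points higher from compound 1 to compound 2 (within the scatter), lies within the usual scatter, so compound 2 cannot be set apart from compound 1 on these two numbers; they read as the same result.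

Compound 3, `COc1cc(C2=NN(C(C)=O)C(c3cccc(F)c3)O2)cc(OC)c1OC`, differs from compound 2 in one place: 3-fluorophenyl in place of 4-(trifluoromethyl)phenyl on a saturated ring carbon. For the measured compounds named here, the single measured step bears directly on this, since it also exchanged the group on that same saturated ring carbon, and it was a number 5.6 percentage points higher from compound 1 to compound 2 (within the scatter). Going by the values given here, with that as the only guide, no step beyond the scatter is expected here, a number 2.2 percentage points lower from compound 2 to compound 3 (within the scatter). Compound 3 is therefore estimated at 2% in this assay, with a range from -10% to 14%.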

Compound 3, a percentage reported as inhibition, at one concentration (the size of the read-out at that concentration, not a potency): 14.7%
Compound 3: middle estimate off by 12.7 percentage points, on the low side, and the stated range ends below it.
By their numbers in this assay, from the lowest: compounds 1 and 2 (each within the scatter of the next); then compound 3.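

The group on this saturated ring carbon can change the result: in this assay, 3-fluorophenyl in place of 4-(trifluoromethyl)phenyl gives a number 10.5 percentage points higher from compound 2 to compound 3 (beyond the scatter) and 3-fluorophenyl in place of 2,6-dichlorophenyl gives a number 16.1 percentage points higher from compound 1 to compound 3 (beyond the scatter), both modest but beyond the scatter. The first two compounds could not be told apart, whereas compound 3 now stands apart from each of them. No available evidence explains this difference.

Replacing 4-(trifluoromethyl)phenyl with 3-fluorophenyl changes both the substituent and where it sits on the phenyl ring, so the compounds shown cannot separate those two changes. On these data alone, how 4-fluorophenyl, or a phenyl ring carrying an amine or a carboxylic acid, would read on this carbon remains open.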